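Aminomethylphenyl position shift on the shared core

A few compounds are considered here, and "the series" means these few. Any claim that something is new, unique, unknown or untested is made for them only; others in the source may bear on it.

Going by the values given here, compound 2 `NCc1ccccc1CN(C[C@H]1Cc2ccccc2CN1)[C@H]1CCCc2cccnc21` gives 50.8 nM in a functional assay on cells for antagonist activity at C-X-C chemokine receptor type 4 (Homo sapiens), read by fluorescence and calcium flux, with stated times of 25 min and 90 s (a lower number here means a stronger inhibitor, a higher number a weaker inhibitor), the higher of the two numbers so far; the nearer of them is compound 1 `c1ccc2c(c1)CN[C@@H](CN(CCCCNCc1ccncc1)[C@H]1CCCc3cccnc31)C2`, which gives 22.7 nM in this assay. Among the compounds with values here, the one measured step, a 2.2-fold higher number from compound 1 to compound 2 (0.35 log units; beyond the scatter), was modest and beyond the scatter.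

The next compound, compound 3 `NCc1cccc(CN(C[C@H]2Cc3ccccc3CN2)[C@H]2CCCc3cccnc32)c1`, differs from compound 2 by 3-(aminomethyl)phenyl in place of 2-(aminomethyl)phenyl on a saturated chain carbon bound to an amine nitrogen. Within the data shown here, the step from compound 1 to compound 2 exchanged a whole side chain for the aminomethylphenyl group, whereas the change to compound 3 keeps that group and only alters where the aminomethyl sits on the ring; no measured step therefore bears on it, and the measured step gives no direction for it. With nothing in this series pointing either way, the expectation is no step beyond the scatter, and compound 3 is estimated to sit close to compound 2, which amounts to an expected 1.1-fold higher number from compound 2 to compound 3 (0.03 log units; within the scatter). The estimate for compound 3 in this assay is 55 nM, with a range from 20 nM to 160 nM.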

Compound 3, half-maximal inhibitory concentration: 292 nM
Beside the measured number, compound 3's estimate is 5.3-fold (0.73 log units) below it; the measured number lies above the stated range.
By their numbers in this assay, from the lowest: compound 1; then compound 2; then compound 3.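

In this assay, the change from 2-(aminomethyl)phenyl to 3-(aminomethyl)phenyl gives a 5.7-fold higher number from compound 2 to compound 3 (0.76 log units; beyond the scatter), so at this position the result depends on where the aminomethyl group sits on the ring and not only on which atoms are present, since the two compounds have the same atoms, joined differently. Against the 3-(((pyridin-4-yl)methyl)amino)propyl side chain, the 3-(aminomethyl)phenyl group gives a 13-fold higher number from compound 1 to compound 3 (1.11 log units; beyond the scatter), a large step, whereas the 2-(aminomethyl)phenyl group stayed closer to compound 1, so among these three compounds the penalty for replacing that side chain depends strongly on the ring position of the aminomethyl group. Nothing available accounts for the difference between the two aminomethylphenyl groups.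

The compounds shown leave open how 4-(aminomethyl)phenyl would read at this position, and so whether the number keeps rising as the aminomethyl group moves around the ring. Also open, on these data alone, is whether a longer chain, such as 2-(2-aminoethyl)phenyl, or a secondary amine in place of the primary amine of 2-(aminomethyl)phenyl, would bring the number closer to that of compound 1.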